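Sulfonyl in place of carbonyl on compound 3

The source may hold more compounds than are shown below. What is called first, only, known or untested is meant among the compounds shown, and "the series" means these compounds.

compound 1 `COc1ccc(/C=C/C(=O)c2ccc(OC)c3c2OC(C)(C)C=C3)cc1OCC=C(C)C` > 10000 nM
compound 2 `CCCCC(=O)Oc1cc(/C=C/C(=O)c2ccc(OC)c3c2OC(C)(C)C=C3)ccc1OC` 100 nM
compound 3 `COc1ccc(/C=C/C(=O)c2ccc(OC)c3c2OC(C)(C)C=C3)cc1OC(=O)c1ccc(Br)cc1` 680 nM

In a functional assay on HepG2 cells (Homo sapiens) for cytotoxicity, read by MTT assay (on this read-out higher numbers stand for weaker inhibition and lower numbers for stronger inhibition), compound 3 gives 680 nM, the higher of the two actual numbers, and compound 2 gives 100 nM. Compound 1 is recorded only as a limit, > 10000 nM.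

The next compound is compound 4 `COc1ccc(/C=C/C(=O)c2ccc(OC)c3c2OC(C)(C)C=C3)cc1OS(=O)(=O)c1ccc(C)cc1`, with (4-methylphenyl)sulfonyl in place of (4-bromophenyl)carbonyl on an oxygen on an aromatic ring. The carbonyl link is lost, while the six-membered aromatic ring stays.

Going by the values given here, three measured steps bear on this. Two are large, an at least 100-fold lower number from compound 1 to compound 2 (2.00 log units; beyond the scatter) and an at least 14-fold lower number from compound 1 to compound 3 (1.16 log units; beyond the scatter), and both bring in a carbonyl-linked group in place of 3-methylbut-2-en-1-yl. The third is modest, a 6.8-fold higher number from compound 2 to compound 3 (0.83 log units; beyond the scatter), and changes only what the carbonyl carries. Among the compounds with values here, no measured step replaces the carbonyl itself, so the transfer is uncertain. Compound 1 lacks that carbonyl and gives only its limit in > 10000 nM, which points to a higher number rather than a lower one.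

A modest change is expected, a 2.9-fold higher number from compound 3 to compound 4 (0.47 log units; beyond the scatter). The estimate for compound 4 is 2000 nM, with an expected range of 400 nM to 9000 nM.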

Compound 4, half-maximal inhibitory concentration: 3600 nM
The estimate for compound 4 lay 1.8-fold (0.26 log units) below the measured number, and the stated range covers the measured number.
By their numbers in this assay, from the lowest: compound 2; then compound 3; then compound 4. At a limit, above all of these: compound 1.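

In this assay, going by these compounds alone, the step to compound 4 is the first that replaces the carbonyl link at this oxygen on an aromatic ring, and it gives a 5.3-fold higher number from compound 3 to compound 4 (0.72 log units; beyond the scatter), although the ring substituent changes in the same step. Set against the butylcarbonyl group, the same position shows a 36-fold higher number from compound 2 to compound 4 (1.56 log units; beyond the scatter), while against the 3-methylbut-2-en-1-yl group it shows an at least 2.7-fold lower number from compound 1 to compound 4 (0.44 log units; beyond the scatter), so among these compounds the (4-methylphenyl)sulfonyl group falls above both carbonyl-linked groups and under the ether group. Compound 1 is a limit and not a number, so its step reads only as a minimum: the limit of > 10000 nM in this assay, at which 1 of the 4 values shown sits.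

The compounds shown do not separate the sulfonyl link from the exchange of bromine for methyl on the ring; a (4-bromophenyl)sulfonyl or a (4-methylphenyl)carbonyl group would divide that step into its two parts. Also open, going by these compounds, is whether a butylsulfonyl group, with the chain of compound 2 on the sulfonyl link, would stay nearer compound 2 or compound 4 in this assay.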